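A few compounds are considered here, and "the series" means these few. Any claim that something is new, unique, unknown or untested is made for them only; others in the source may bear on it.

Compound 1 `Cc1cc(NNC(=O)Nc2cc(Cl)nc(Cl)c2)ncc1-c1cnn(C)c1` in a functional assay on CHO cells for agonist activity at sphingosine 1-phosphate receptor 2 (Homo sapiens), read by fluorescence and calcium flux, with a stated time of 3 min (a higher number here means a weaker inhibitor, a lower number a stronger inhibitor), gives > 23000 nM, which is a limit of the assay and not a number. Compound 2 `CCOc1cc(NC(=O)NCc2cc(C)c(-c3cn(C)nc3C)cn2)cc(Cl)n1` gives 4700 nM in this assay. Compound 3 `CCOc1cc(NC(=O)NCc2cc(C)c(-c3cn(C)nc3C(F)(F)F)cn2)cc(Cl)n1` gives 4400 nM in this assay, the lowest of the two numbers shown; its nearest neighbour is compound 2, and since the step of a 1.1-fold lower number from compound 2 to compound 3 (0.03 log units; within the scatter) lies within the scatter, the two compounds cannot be told apart on these numbers.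

Compound 4 `CCOc1cc(NC(=O)NCc2cc(C)c(N3CC(C)OC(C)C3)cn2)cc(Cl)n1` has not yet been measured. It differs from compound 3 by 2,6-dimethylmorpholin-4-yl in place of 1-methyl-3-(trifluoromethyl)-1H-pyrazol-4-yl on an aromatic carbon. Among the measured compounds shown here, the only measured step in this assay concerns a different exchange, trifluoromethyl for methyl on that same five-membered ring, and that step was within the scatter. For the measured compounds named here, no measured pair covers the replacement of the whole five-membered aromatic ring by a six-membered non-aromatic ring, so the expectation rests on little. Compound 4 is therefore expected to stay near compound 3, with the estimated step of a 1.3-fold higher number from compound 3 to compound 4 (0.10 log units; within the scatter) carrying a wide range. The estimate for compound 4 in this assay is 5500 nM, between 1500 nM and 20000 nM.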

Compound 4, half-maximal inhibitory concentration: 4200 nM
Compound 4: middle estimate off by 1.3-fold (0.12 log units), on the high side; the range from low to high includes it.
By their numbers in this assay, from the lowest: compounds 4, 3 and 2 (each within the scatter of the next). At a limit, above all of these: compound 1.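

In this assay the exchange of the five-membered aromatic ring for the six-membered non-aromatic 2,6-dimethylmorpholin-4-yl gives a 1.0-fold lower number from compound 3 to compound 4 (0.02 log units; within the scatter) and, starting from the 1,3-dimethyl-1H-pyrazol-4-yl group, a 1.1-fold lower number from compound 2 to compound 4 (0.05 log units; within the scatter) on the same aromatic carbon. The earlier pair covered only a trifluoromethyl for methyl exchange on the five-membered ring, whereas these steps show that replacing the whole ring, aromatic or not, leaves compounds 2, 3 and 4 indistinguishable on these numbers. Nothing shown here gives a cause for this result.

No group shown at this position separates itself from the others beyond the scatter, so it remains open whether any group here can shift the number. A piperazine, a carboxylic acid or a longer alkyl chain in this place might show that, and the compounds shown do not say.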